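The compounds below may be only part of what the source reports. "The series", "measured", "known", "first", "only" and "open" are said of these compounds alone.

Series notes, D4 displacement set.

Three compounds have a number in an assay on HEK293 cells for displacement of a labelled ligand from D(4) dopamine receptor (Homo sapiens), read by scintillation counting, with a stated time of 60 min (a lower number here means a stronger inhibitor, a higher number a weaker inhibitor), so far. Compound 1 `Cc1cccc(NC(=O)CN2CCC(c3ccc(Cl)cc3)CC2)c1` gives 115 nM in this assay. Compound 3 `CCc1cccc(NC(=O)CN2CCN(c3ccc(Cl)cn3)CC2)c1` gives 172 nM in this assay. Compound 2 `O=C(CN1CCN(c2ccccn2)CC1)Nc1cccnc1` gives 6410 nM in this assay, the highest of the three numbers; its gap to compound 3 and its gap to compound 1 both lie beyond the scatter, so compound 2 is the weakest binder of the set as measured. Compounds 1 and 3 differ from compound 2 in more than one place, so no single-change step can be read from them.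

Compound 4 `O=C(CN1CCN(c2ccccn2)CC1)Nc1cncnc1` is the next analogue. Relative to compound 2 the change is pyrimidin-5-yl in place of pyridin-3-yl on an amide-type nitrogen. Within the data shown here, no measured pair in the set isolates this change, so there is no directly comparable step to lean on. The expectation is a small step, if any, from compound 2 to compound 4, estimated as a 1.4-fold higher number from compound 2 to compound 4 (0.15 log units; within the scatter), leaning toward a somewhat higher number, with a real chance that this assay reports only a limit for compound 4. Compound 4 is accordingly estimated at 9000 nM in this assay, with a likely range from 3000 nM to 27000 nM.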

Compound 4, inhibition constant: 39300 nM
For compound 4 the middle estimate is 4.4-fold (0.64 log units) below the measured one; measured number above the stated range.
By their numbers in this assay, from the lowest: compounds 1 and 3 (each within the scatter of the next); then compound 2; then compound 4.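

In this assay, among these compounds, pyrimidin-5-yl in place of pyridin-3-yl on the amide-type nitrogen gives a 6.1-fold higher number from compound 2 to compound 4 (0.79 log units; beyond the scatter), the only single-change step in the set so far. This shows that the position responds to a change that leaves the heavy-atom count and the six-membered aromatic ring in place, and alters only the count of ring hetero atoms and hydrogen-bond acceptors, with compound 4 at 39300 nM now the highest number in the series. No measurement in hand speaks to the origin of this step.

One pair cannot show whether the upward move follows the added ring nitrogen in general or belongs to this particular pair of rings, so the reading holds for compound 2 and compound 4 only. Still open, as far as these compounds go, is how a plain phenyl, a pyridin-4-yl or a saturated cyclohexyl on the same amide-type nitrogen would read against the core of compound 2, and whether the same exchange would give a step of similar size on a different core.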